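The compounds below may be only part of what the source reports. "The series", "measured", "known", "first", "only" and "open" are said of these compounds alone.

In a functional assay on MDA-MB-231 cells (Homo sapiens) for cytotoxicity, read by MTT assay, with a stated time of 48 h (on this read-out lower numbers stand for stronger inhibition and higher numbers for weaker inhibition), compound 1 `COc1cc(C2=NOC(c3cc(OC)c(OC)c(OC)c3)C2)ccc1O` gives 3600 nM, compound 2 `COc1ccc(C2=NOC(COc3ccc(-c4nnnn4-c4cc(OC)c(OC)c(OC)c4)cc3N)C2)cc1N` gives 3000 nM and compound 3 `COc1cc(C2=NOC(COc3ccc(-c4nnnn4-c4cc(OC)c(OC)c(OC)c4)cc3N)C2)cc(OC)c1OC` gives 3230 nM, so compound 2 stands level with the other two, all within the usual scatter. Compound 4 `COc1cc(C2=NOC(COc3ccc(-c4nnnn4-c4cc(OC)c(OC)c(OC)c4)cc3N)C2)ccc1O` differs from compound 2 in one place: 4-hydroxy-3-methoxyphenyl in place of 3-amino-4-methoxyphenyl on a carbon with a double bond to nitrogen. Within the data shown here, the one measured step at that place is a 1.1-fold higher number from compound 2 to compound 3 (0.03 log units; within the scatter), with 3,4,5-trimethoxyphenyl entering there. Compound 1, at 3600 nM, carries the same 4-hydroxy-3-methoxyphenyl as compound 4, but the rest of its structure is different. No shift beyond the scatter is therefore expected in this assay, and the expected step is no change at the digits printed from compound 2 to compound 4 (within the scatter). For compound 4 the estimated value is 3000 nM, with an expected range of 1300 nM to 7000 nM.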

Compound 4, half-maximal inhibitory concentration: 3620 nM
For compound 4 the middle estimate is 1.2-fold (0.08 log units) below the measured one; the range from low to high includes it.
By their numbers in this assay, from the lowest: compounds 2, 3, 1 and 4 (each within the scatter of the next).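

In this assay, 4-hydroxy-3-methoxyphenyl gives a 1.2-fold higher number from compound 2 to compound 4 (0.08 log units; within the scatter), and set against 3,4,5-trimethoxyphenyl it gives a 1.1-fold higher number from compound 3 to compound 4 (0.05 log units; within the scatter). Among these compounds, this position on the shared core has now carried three differently substituted phenyl groups, and no step between them goes beyond the scatter. Nothing shown here offers a reason for this flat result.

All three groups keep at least one methoxy, so the compounds shown leave open whether an unsubstituted phenyl, a carboxylic acid or a longer alkyl chain at this place would move the number.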